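Fluoro substitution on the aryl group of a nucleoside analogue

A few compounds are considered here, and "the series" means these few. Any claim that something is new, unique, unknown or untested is made for them only; others in the source may bear on it.

Compound 1, `Nc1ncnn2c([C@@H]3O[C@H](CO)[C@@H](O)[C@H]3O)cc(C#Cc3ccc(F)cc3)c12`, in a functional assay on HCT-116 cells (Homo sapiens) for antiproliferative activity, with a stated time of 72 h (a higher number here means a weaker inhibitor, a lower number a stronger inhibitor), gives > 100000 nM, which is a limit of the assay and not a number.
Compound 2, `Nc1ncnn2c([C@@H]3O[C@H](CO)[C@@H](O)[C@H]3O)cc(C#Cc3ccccc3)c12`, in this assay gives 46900 nM.
Compound 3, `Nc1ncnn2c([C@@H]3O[C@H](CO)[C@@H](O)[C@H]3O)cc(-c3ccccc3F)c12`, in this assay gives > 100000 nM, again a limit of the assay and not a number.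

Compound 2 and compound 1 differ only by fluoro in place of hydrogen on an aromatic carbon, and the step of an at least 2.1-fold higher number from compound 2 to compound 1 (0.32 log units; beyond the scatter) is cut off by the limit of > 100000 nM in this assay, at which 2 of the 3 values shown sit. Compound 2 and compound 3 differ in their cores by 2-fluorophenyl in place of 2-phenylethynyl on an aromatic carbon; the step of an at least 2.1-fold higher number from compound 2 to compound 3 (0.32 log units; beyond the scatter) is likewise bounded by the limit, and a step that the two limits leave unreadable from compound 1 to compound 3 cannot be read.

Compound 4, `Nc1ncnn2c([C@@H]3O[C@H](CO)[C@@H](O)[C@H]3O)cc(-c3ccc(F)cc3F)c12`, has not been measured in this assay. It differs from compound 3 by fluoro in place of hydrogen on an aromatic carbon, the same kind of change as that from compound 2 to compound 1, though here the entering fluoro sits meta to a fluoro group as well as para to a large group. Given that compound 3 already sits at the limit and the same kind of change gave an at least 2.1-fold higher number from compound 2 to compound 1 (0.32 log units; beyond the scatter), compound 4 is expected to remain at or beyond that limit, with a step that the limit leaves unreadable from compound 3 to compound 4. Compound 4 is therefore estimated at 150000 nM, between 60000 nM and 400000 nM.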

Compound 4, half-maximal inhibitory concentration: 59500 nM
Estimate against measurement, compound 4: 2.5-fold (0.40 log units) above, outside the stated range (below it).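

In this assay, fluoro in place of hydrogen on the core of compound 3 gives an at least 1.6-fold lower number from compound 3 to compound 4 (0.22 log units; that floor lies within the scatter), so the change does not carry over from the core of compound 2 with the same direction: the same change on two cores in this assay, an at least 2.1-fold higher number (0.32 log units; beyond the scatter) from compound 2 to compound 1 and an at least 1.6-fold lower number (0.22 log units; that floor lies within the scatter) from compound 3 to compound 4, at least 3.5-fold (0.55 log units) apart, beyond the scatter of two such steps What this does not show is the true size of either fluoro step, since each has one end at a limit of the assay: the limit of > 100000 nM in this assay, at which 2 of the 4 values shown sit. Between the aryl groups themselves, there is a 1.3-fold higher number from compound 2 to compound 4 (0.10 log units; within the scatter), which stays within the scatter, and an at least 1.6-fold lower number from compound 1 to compound 4 (0.22 log units; that floor lies within the scatter), whose floor also lies within the scatter.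

The compounds shown leave open whether this split follows the 2-phenylethynyl group as against the 2-fluorophenyl group or rests on these two pairs alone. They also leave open how a chloro, a methoxy or an amine would behave in the place taken by the entering fluoro.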